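This account rests on a few compounds, and the source may have more. Where it says the series, first, only, none or still open, it means among the compounds named here.

Compound 1, `Nc1ccc(C(=O)/C=C/c2ccco2)cc1`: 38% in a functional assay on the whole organism (strain albino) for inhibition, with Rattus norvegicus as the target, read by paw edema, with stated times of 30 min and 2 h, at a dose of 100 mg/kg by the oral route; on this read-out higher numbers stand for more inhibition at the one dose given (going by the name of the read-out) and lower numbers for less inhibition.
Compound 2, `O=C(CO[N+](=O)[O-])Nc1ccc(C(=O)/C=C/c2ccc(Cl)cc2)cc1`: 57%.
Compound 3, `COc1ccc(/C=C/C(=O)c2ccc(NC(=O)CO[N+](=O)[O-])cc2)cc1`: 49%.

In this assay compound 3 stands second highest of the three numbers; its nearest neighbour is compound 2, with a number 8 percentage points lower from compound 2 to compound 3 (within the scatter), while compound 1 lies farther off, beyond the scatter. Compound 4, `O=C(CO[N+](=O)[O-])Nc1ccc(C(=O)/C=C/c2ccco2)cc1`, is not yet measured. It differs from compound 3 by furan-2-yl in place of 4-methoxyphenyl on a double-bonded chain carbon bound to a double-bonded chain carbon. Among the compounds with values here, no measured step covers this change directly: the one single-place step, from chloro to methoxy, stayed within the scatter, and compound 1 shows the furan-2-yl group only on a different core. Compound 4 is therefore expected to give 45%, within 33% to 57%. The expected step is a number 4 percentage points lower from compound 3 to compound 4 (within the scatter).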

Compound 4, a percentage reported as inhibition, in the whole organism at one dose (the size of the read-out at that dose, not a potency): 36%
Compound 4: middle estimate off by 9 percentage points, on the high side, within the range that was stated.
By their numbers in this assay, from the lowest: compounds 4 and 1 (each within the scatter of the next); then compounds 3 and 2 (each within the scatter of the next).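

At the double-bonded chain carbon, changing the ring moved the number, as the earlier chloro-to-methoxy step had not: in this assay, furan-2-yl in place of 4-methoxyphenyl gave a number 13 percentage points lower from compound 3 to compound 4 (beyond the scatter) and furan-2-yl in place of 4-chlorophenyl gave a number 21 percentage points lower from compound 2 to compound 4 (beyond the scatter) as well. With furan-2-yl present, ((nitrooxy)methyl)carbonyl in place of hydrogen on the nitrogen gave only a number 2 percentage points lower from compound 1 to compound 4 (within the scatter) in the same read-out. Nothing measured here explains these differences. From the compounds shown here alone, whether a thiophene or an unsubstituted phenyl at this position would stand with furan-2-yl or with the substituted phenyl rings remains open. So does the effect of that nitrogen change when 4-chlorophenyl or 4-methoxyphenyl is present.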